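This account rests on a few compounds, and the source may have more. Where it says the series, first, only, none or still open, it means among the compounds named here.

Compound 1 `COCc1ncc2cnnc(S)n12`: > 48000 nM
Compound 2 `CCCc1ncc2cnnc(S)n12`: > 48000 nM

In a functional assay for inhibition, with Homo sapiens as the target (a lower number here means a stronger inhibitor, a higher number a weaker inhibitor), compound 1 gives > 48000 nM, which is a limit of the assay rather than a number. Compound 2 likewise gives only a limit, > 48000 nM. The step that the two limits leave unreadable from compound 1 to compound 2 therefore cannot be read. Compound 3 `C=CCSc1nncc2cnc(COC)n12` differs from compound 1 by allyl in place of hydrogen on a sulfur. Going by the values given here, no measured step touches a change on the sulfur, and both measured values share (the limit of > 48000 nM in this assay, at which 2 of the 2 values shown sit), so neither size nor direction can be taken from them. Compound 3 is expected to remain weak, with an estimated step that the limit leaves unreadable from compound 1 to compound 3. The estimated value for compound 3 is 60000 nM, between 8000 nM and 300000 nM.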

Compound 3, half-maximal inhibitory concentration: 79000 nM
Compound 3: middle estimate off by 1.3-fold (0.12 log units), on the low side; the range from low to high includes it.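

Compound 1 gives only a limit of the assay, > 48000 nM. Going by these compounds alone, compound 3 gives 79000 nM, so no step between compound 1 and compound 3 can be read. As far as these compounds go, whether allyl on the sulfur changes inhibition at all stays open.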